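Dimethylcarbamoyl to methyl: notes on compound 3

The compounds below may be only part of what the source reports. "The series", "measured", "known", "first", "only" and "open" are said of these compounds alone.

In a functional assay on HT-29 cells (Homo sapiens) (on this read-out higher numbers stand for an effect only at larger amounts of compound and lower numbers for an effect already at smaller amounts), so far
- compound 1 `NC(=O)Nc1sc(-c2ccc(C(=O)N3CCOCC3)cc2)cc1C(=O)N[C@H]1CCCNC1` gives 610 nM
- compound 2 `CN(C)C(=O)c1ccc(-c2cc(C(=O)N[C@H]3CCCNC3)c(NC(N)=O)s2)cc1` gives 320 nM

Compound 2 stands level with compound 1 within the scatter. Compound 3 `Cc1ccc(-c2cc(C(=O)N[C@H]3CCCNC3)c(NC(N)=O)s2)cc1` carries methyl in place of dimethylcarbamoyl on an aromatic carbon, para to a large group (methyl in place of dimethylcarbamoyl on an aromatic carbon). Going by the values given here, the one measured step (a 1.9-fold lower number from compound 1 to compound 2 (0.28 log units; within the scatter)) puts dimethylamino in place of morpholin-4-yl on a carbonyl carbon and stays within the scatter, but it keeps the carbonyl that this change removes. Among the compounds with values here, no measured step removes it, so the guidance is weak and no step beyond the scatter is expected in either direction. The expected step (a 1.1-fold lower number from compound 2 to compound 3 (0.06 log units; within the scatter)) is only an estimate. For compound 3 the estimate is 280 nM (expected range 90 nM to 900 nM).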

Compound 3, half-maximal effective concentration: 70 nM
Compound 3: middle estimate off by 4.0-fold (0.60 log units), on the high side; the whole stated range lies above it.
By their numbers in this assay, from the lowest: compound 3; then compounds 2 and 1 (each within the scatter of the next).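

Taking the whole carbonyl-bearing group off this aromatic carbon, para to a large group, moves the number beyond the scatter in this assay where exchanging the group on the carbonyl did not: methyl in place of dimethylcarbamoyl gives a 4.6-fold lower number from compound 2 to compound 3 (0.66 log units; beyond the scatter) and methyl in place of (morpholin-4-yl)carbonyl gives an 8.7-fold lower number from compound 1 to compound 3 (0.94 log units; beyond the scatter) in the same direction. The carbonyl is therefore not required here for an effect at smaller amounts, and compound 3 has the lowest number of the three, with both its steps beyond the scatter. Nothing at hand accounts for these steps.

With a single replacement group, loss of the carbonyl and loss of heavy atoms cannot be told apart. As far as these compounds go, how ethyl, a chlorine atom or a primary amine on this carbon would compare with methyl remains open.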